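This account rests on a few compounds, and the source may have more. Where it says the series, first, only, none or still open, it means among the compounds named here.

Working notes on the series.

Compound 1 `COc1ncc(-c2ccc3c(c2)NC(=O)CO3)cc1NS(=O)(=O)c1ccc(F)cc1` gives 32300 nM in a functional assay on MCF7 cells (Homo sapiens) for antiproliferative activity, read by MTT assay, with a stated time of 72 h; on this read-out higher numbers stand for weaker inhibition and lower numbers for stronger inhibition. Compound 3 `COc1ncc(-c2ccc3c(c2)N(c2ccc(Cl)cc2)C(=O)CO3)cc1NS(=O)(=O)c1ccc(F)cc1` carries 4-chlorophenyl in place of hydrogen on an amide-type nitrogen in a ring relative to compound 1, and in this assay compound 3 gives 27600 nM; the step is a 1.2-fold lower number from compound 1 to compound 3 (0.07 log units; within the scatter), so the two sit together.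

Compound 2 `O=C1COc2ccc(-c3cnc4ccccc4c3)cc2N1` has a different core, and how the two cores differ is not broken down here. In this assay compound 2 gives only a limit of the assay, > 40000 nM, not a number.

Compound 4 `O=C1COc2ccc(-c3cnc4ccccc4c3)cc2N1c1ccc(Cl)cc1` carries 4-chlorophenyl in place of hydrogen on an amide-type nitrogen in a ring relative to compound 2; the place of the change reads the same as in the step from compound 1 to compound 3, so this is the same change on the second core. Its step is not yet measured in this assay.

Expectation: the step is estimated as a step that the limit leaves unreadable from compound 2 to compound 4, resting on the step of a 1.2-fold lower number from compound 1 to compound 3 (0.07 log units; within the scatter) being within the scatter and on compound 2 sitting at the limit of > 40000 nM in this assay, at which 1 of the 3 values shown sits. Compound 4 is therefore estimated at 45000 nM, with an expected range from 20000 nM to 100000 nM, and a further limit reading is the more likely outcome.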

Compound 4, half-maximal inhibitory concentration: > 40000 nM
Compound 4 ended at the assay's limit (the forecaster's own chance of this, stated with the estimate: 70%); the middle value lies beyond the limit too.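

In this assay compound 4 gives > 40000 nM as a limit of the assay, not a number. Compound 2 also stands at a limit, so no step can be read from compound 2 to compound 4. The compounds shown leave open whether 4-chlorophenyl on the amide-type nitrogen changes the read-out on the core of compound 2.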